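Replacing 3-bromophenyl with 4-fluorophenyl in a level series

The source may report more compounds than this note shows. Statements on the series, on what has been measured and on what is new or still open speak of the compounds shown alone.

Of the compounds shown here, three that share one core have been tested so far in a functional assay on the whole organism (strain Kunming) with Mus musculus as the target, in the formalin test, with a stated time of 0.5 h; on this read-out lower numbers stand for an effect already at smaller amounts and higher numbers for an effect only at larger amounts of compound. Compound 1 (`COc1cc(OC)c(OC)cc1/C=C/COC(=O)/C=C/c1ccc(OC)c(OC)c1`) gives 225 umol/kg, compound 2 (`COc1cc(OC)c(OC)cc1/C=C/COC(=O)/C=C/c1ccc(Br)cc1`) gives 243 umol/kg, and compound 3 (`COc1cc(OC)c(OC)cc1/C=C/COC(=O)/C=C/c1cccc(Br)c1`) gives 260 umol/kg. Compound 3 therefore stands level with the other two, since neither of its steps to them exceeds the normal scatter between repeated measurements.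

The next compound, compound 4 (`COc1cc(OC)c(OC)cc1/C=C/COC(=O)/C=C/c1ccc(F)cc1`), has not yet been measured. It carries 4-fluorophenyl in place of 3-bromophenyl, on a double-bonded chain carbon bound to a double-bonded chain carbon: 4-fluorophenyl in place of 3-bromophenyl on a double-bonded chain carbon bound to a double-bonded chain carbon.

Three measured steps exchange this same group. They are a 1.1-fold higher number from compound 1 to compound 2 (0.03 log units; within the scatter), a 1.2-fold higher number from compound 1 to compound 3 (0.06 log units; within the scatter) and a 1.1-fold higher number from compound 2 to compound 3 (0.03 log units; within the scatter), and all three stay within the scatter. As far as these compounds go, none of them involves 4-fluorophenyl, so the new group itself remains untested, and the expectation rests only on how little these exchanges have changed the numbers so far.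

No step beyond the scatter is therefore expected in this assay, and the expected step is a 1.1-fold lower number from compound 3 to compound 4 (0.03 log units; within the scatter). For compound 4 the estimated value is 240 umol/kg, with an expected range of 120 umol/kg to 460 umol/kg.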

Compound 4, dose for half-maximal effect: 117 umol/kg
Estimate against measurement, compound 4: 2.1-fold (0.31 log units) above, outside the stated range (below it).
By their numbers in this assay, from the lowest: compounds 4, 1, 2 and 3 (each within the scatter of the next, the first and the last beyond it).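

In this assay the earlier exchanges on this double-bonded chain carbon had all stayed level, so the position could have seemed indifferent to the choice of aryl group, but 4-fluorophenyl in place of 3-bromophenyl gives a 2.2-fold lower number from compound 3 to compound 4 (0.35 log units; beyond the scatter) and moves the number beyond the scatter. The simplest exchange is fluoro in place of bromo on an aromatic carbon, which gives a 2.1-fold lower number from compound 2 to compound 4 (0.32 log units; beyond the scatter) and shows that the halogen on the ring matters here, even though moving bromine from 4-bromophenyl to 3-bromophenyl made no difference beyond the scatter. Against the 3,4-dimethoxyphenyl group the result is a 1.9-fold lower number from compound 1 to compound 4 (0.28 log units; within the scatter) and stays within the scatter, so the fluorine compound stands apart only from the two bromine compounds and not from every earlier compound.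

Nothing shown here bears on why fluoro and bromo differ in this way.

As far as these compounds go, with fluoro seen only as 4-fluorophenyl, it remains open whether 3-fluorophenyl would give a similar number or whether the 4-position matters for fluorine. From the compounds shown here alone, it is also open whether the trend continues with a plain phenyl ring or with chloro, a nitrile or an amine on the ring.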